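This account rests on a few compounds, and the source may have more. Where it says the series, first, only, none or still open, it means among the compounds named here.

Measured so far:
compound 1 `CCOc1ccc(Cl)c(-c2ccc(OCCCC(=O)O)cc2)c1` gives 1130 nM
compound 2 `CCOc1ccc(F)c(-c2ccc(OCCCC(=O)O)cc2)c1` gives 3190 nM
compound 3 `Cc1cc(-c2cc(OC(F)(F)F)ccc2Cl)ccc1OCCCC(=O)O` gives 6720 nM

All three numbers come from a functional assay on isolated protein for agonist activity at Free fatty acid receptor 1 (Homo sapiens), read by HTRF and inositol phosphate accumulation, with a stated time of 60 min; a lower number here means that less compound is needed, a higher number that more compound is needed for the effect. Compound 1 and compound 2 share one core and differ in a single place, (fluoro in place of chloro on an aromatic carbon), and this change produced a 2.8-fold higher number from compound 1 to compound 2 (0.45 log units; beyond the scatter). Compound 3 carries a different core; how its core differs from that of compound 1 is not broken down here. In this assay compound 3 stands at the highest of the three numbers, above compound 2 and further above compound 1, both gaps beyond the usual scatter.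

Compound 4 `Cc1cc(-c2cc(OC(F)(F)F)ccc2F)ccc1OCCCC(=O)O` is not yet measured. It is related to compound 3 by fluoro in place of chloro on an aromatic carbon. This is the same kind of change as that from compound 1 to compound 2, though the surroundings of the place are not identical: in compound 4 the exchanged atom is para to a trifluoromethoxy group, whereas in compound 2 it is para to an ethoxy group. Among the compounds with values here, with only one earlier instance of the change, and on a different core, the comparison rests on that single step. The step from compound 3 to compound 4 is expected to be a 2.7-fold higher number from compound 3 to compound 4 (0.43 log units; beyond the scatter) in this assay, set beside a 2.8-fold higher number from compound 1 to compound 2 (0.45 log units; beyond the scatter) on the assumption that the exchange behaves alike on both cores. On that basis compound 4 is estimated at 18000 nM, with a range from 7000 nM to 50000 nM, and since compound 3 already sits high, a limit rather than a number is a real possibility.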

Compound 4, half-maximal effective concentration: 9260 nM
The estimate for compound 4 lay 1.9-fold (0.29 log units) above the measured number, within the range that was stated.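

In this assay, fluoro in place of chloro on an aromatic carbon gives a 1.4-fold higher number from compound 3 to compound 4 (0.14 log units; within the scatter), so on this core the exchange cannot be told apart from repeat measurement. Set beside the earlier instance, the two steps do not differ, and nothing here marks the exchange as behaving differently on the two cores: the same change on two cores in this assay, a 2.8-fold higher number (0.45 log units; beyond the scatter) from compound 1 to compound 2 and a 1.4-fold higher number (0.14 log units; within the scatter) from compound 3 to compound 4, 2.0-fold (0.31 log units) apart, within the scatter of two such steps. This rests on two pairs only and fixes no size for the change, since one step lies beyond the scatter and the other within it; nor can any influence of the core be separated from that of the trifluoromethoxy group in compound 4, set against the ethoxy group in compound 2.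

The compounds shown leave open how other groups on the same aromatic carbon, such as bromo or a nitrile, would read in this assay, and whether the exchange of chloro for fluoro would hold with a trifluoromethyl group in place of the trifluoromethoxy group. They also leave open how either pair would respond with a tetrazole in place of the carboxylic acid, or with a longer chain carrying the acid.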